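Methylation of the glycinamide amine across two cores

The source may report more compounds than this note shows. Statements on the series, on what has been measured and on what is new or still open speak of the compounds shown alone.

Compound 1 `CNCC(=O)Nc1cc(OC)ccc1C(=O)c1ccc2c(c1)C=CC(C)(C)O2` carries a primary amine on the side chain and gives 850 nM in a functional assay on A2780 cells (Homo sapiens) for antiproliferative activity, read by MTT assay, with a stated time of 48 h; on this read-out higher numbers stand for weaker inhibition and lower numbers for stronger inhibition. Compound 2 `COc1ccc(C(=O)c2ccc3c(c2)C=CC(C)(C)O3)c(NC(=O)CN(C)C)c1` gives 1020 nM in this assay. The change between them is methyl in place of hydrogen on an amine nitrogen, and the step is a 1.2-fold higher number from compound 1 to compound 2 (0.08 log units; within the scatter).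

Compound 3 `C=C(c1cc(OC)c(OC)c(OC)c1)c1ccc(OC)cc1NC(=O)CN` is built on a different core; the difference between the two cores is not broken down here. In this assay compound 3 gives 30 nM, the lowest number of the three measured compounds and beyond the scatter from both compound 1 and compound 2.

Compound 4 `C=C(c1cc(OC)c(OC)c(OC)c1)c1ccc(OC)cc1NC(=O)CNC` is not yet measured. It differs from compound 3 by methyl in place of hydrogen on an amine nitrogen. This is the same kind of change as that from compound 1 to compound 2, though not the same: there the amine nitrogen had two saturated chain carbons as other neighbours, here it has one saturated chain carbon.

Since the earlier step was a 1.2-fold higher number from compound 1 to compound 2 (0.08 log units; within the scatter), the step from compound 3 to compound 4 is expected to be small, a 1.2-fold higher number from compound 3 to compound 4 (0.08 log units; within the scatter). Compound 4 is therefore estimated at 36 nM, with a range from 18 nM to 75 nM.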

Compound 4, half-maximal inhibitory concentration: 140 nM
For compound 4 the middle estimate is 3.9-fold (0.59 log units) below the measured one, outside the stated range (above it).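

In this assay methyl in place of hydrogen on an amine nitrogen gives a 4.7-fold higher number from compound 3 to compound 4 (0.67 log units; beyond the scatter) and the size of this step does not carry over from the core of compound 1 to the core of compound 3: the same change on two cores in this assay, a 1.2-fold higher number (0.08 log units; within the scatter) from compound 1 to compound 2 and a 4.7-fold higher number (0.67 log units; beyond the scatter) from compound 3 to compound 4, 3.9-fold (0.59 log units) apart, beyond the scatter of two such steps.

A step within the scatter on one core is therefore no guide to the same change on the other core in this series. The comparison does not show that the core alone sets the size of the step, since the amine nitrogen also differs between the pairs: its other neighbours are two saturated chain carbons in one pair and one saturated chain carbon in the other.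

Still open, going by these compounds, is how a dimethylamino group on the core of compound 3 and an amino group on the core of compound 1 would read, as these would place both steps on each core. An ethylamino group or a longer chain on the same nitrogen would show whether the step grows with the size of the group.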